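Replacing the aromatic group of compound 2

The source may report more compounds than this note shows. Statements on the series, on what has been measured and on what is new or still open speak of the compounds shown alone.

In a functional assay on MCF7 cells (Homo sapiens) for inhibition, read by MTT assay, with a stated time of 72 h (a lower number here means a stronger inhibitor, a higher number a weaker inhibitor), compound 2 `Nc1ncnc2c1c(-c1cnc3[nH]ccc3c1)nn2CCCCCCCCC(=O)NO` gives 24700 nM, the higher of the two actual numbers in this small set. Compound 1 `CNC(=O)CCCCCCCn1nc(-c2cnc3[nH]ccc3c2)c2c(N)ncnc21` gives 7570 nM, and between the two lies a 3.3-fold higher number from compound 1 to compound 2 (0.51 log units; beyond the scatter), a modest step. Compound 3 `Nc1ncnc2c1c(-c1cnc3[nH]ccc3c1)nn2CCC(=O)NO` reads > 150000 nM, which is a limit of the assay and not a number. The comparison with it is an at least 6.0-fold higher number from compound 2 to compound 3 (0.78 log units; beyond the scatter).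

Compound 4 `Nc1nc2cc(-c3nn(CCCCCCCCC(=O)NO)c4ncnc(N)c34)ccc2o1` keeps the chain of compound 2 and differs in one group: a group of 10 heavy atoms (7 carbon, 2 nitrogen, 1 oxygen; one five-membered aromatic ring with 2 hetero atoms, one six-membered aromatic ring of carbon only) in place of a group of 9 heavy atoms (7 carbon, 2 nitrogen; one five-membered aromatic ring with 1 hetero atom, one six-membered aromatic ring with 1 hetero atom), on an aromatic carbon. The group that enters is 2-amino-1,3-benzoxazol-5-yl, and it sits on an aromatic carbon of a five-membered aromatic ring with 2 nitrogen. For the measured compounds named here, all the measured steps alter the chain or its end, and none alters this aromatic group, so they offer no measure of the size or direction of this change. The expectation therefore starts from compound 2 at 24700 nM and allows wide margins on both sides. No step beyond the scatter is expected in this assay, with a slightly lower number as a tentative lean. The estimated change is a 1.6-fold lower number from compound 2 to compound 4 (0.22 log units; within the scatter). For compound 4 the estimated value is 15000 nM, with an expected range of 4000 nM to 60000 nM.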

Compound 4, half-maximal inhibitory concentration: 42100 nM
The estimate for compound 4 lay 2.8-fold (0.45 log units) below the measured number, within the range that was stated.
By their numbers in this assay, from the lowest: compound 1; then compounds 2 and 4 (each within the scatter of the next). At a limit, above all of these: compound 3.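

In this assay, for the compounds shown here, placing 2-amino-1,3-benzoxazol-5-yl on the aromatic carbon next to the ring nitrogen gives a 1.7-fold higher number from compound 2 to compound 4 (0.23 log units; within the scatter), and this is the first measure of a change at this position rather than in the chain or at its end. The step shows that, with this chain held constant, the group can change from one with a six-membered aromatic ring bearing 1 hetero atom to one with a six-membered aromatic ring of carbon only, and from 1 hydrogen-bond acceptor to 3, without a shift beyond the scatter of this assay. Nothing measured here gives a reason why the exchange has so small an effect.

The compounds shown compare only these two aromatic groups, both on the same chain ending in a hydroxycarbamoyl group, so it remains open whether the result carries over to the methylcarbamoyl chain of compound 1. As far as these compounds go, it is also open how a plain phenyl ring, or a 2-amino-1,3-benzothiazol-5-yl group with sulfur in place of the oxygen, would read at this position.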